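Chloro on the Phenyl Ring and Cytotoxicity in Macrophages

The compounds below may be only part of what the source reports. "The series", "measured", "known", "first", "only" and "open" are said of these compounds alone.

Three compounds have been measured in an ADME assay on J774 cells (Mus musculus) for cytotoxicity, read by MTT assay, with a stated time of 48 h; on this read-out higher numbers stand for weaker inhibition and lower numbers for stronger inhibition:

compound 1, `O=C(/C=C/c1ccc2no[n+]([O-])c2c1)c1ccccc1`, gives 47000 nM
compound 2, `O=C(/C=C/c1ccc2no[n+]([O-])c2c1)c1ccc(Cl)cc1`, gives 28000 nM
compound 3, `O=C(/C=C/c1ccc2nonc2c1)c1ccccc1`, gives 102000 nM

Compound 1 and compound 2 share one core and differ in a single place: chloro in place of hydrogen on an aromatic carbon. In this assay this gave a 1.7-fold lower number from compound 1 to compound 2 (0.22 log units; within the scatter). Compound 3 carries a different core; how the two cores differ is not broken down here. Of the three numbers compound 3 has the highest, and its gaps to compound 1 and to compound 2 both lie beyond the scatter.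

Compound 4, `O=C(/C=C/c1ccc2nonc2c1)c1ccc(Cl)cc1`, has not yet been measured in this assay. It differs from compound 3 by chloro in place of hydrogen on an aromatic carbon, the same change that separates compound 2 from compound 1, and the place is described in the same words in both pairs. Among the compounds with values here, the only guide is the single earlier pair, whose step a 1.7-fold lower number from compound 1 to compound 2 (0.22 log units; within the scatter) was within the scatter, so the step from compound 3 to compound 4 is expected to be a 1.7-fold lower number from compound 3 to compound 4 (0.23 log units; within the scatter). Compound 4 is therefore estimated at 60000 nM in this assay, expected to fall between 30000 nM and 120000 nM.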

Compound 4, half-maximal inhibitory concentration: 251000 nM
The estimate for compound 4 lay 4.2-fold (0.62 log units) below the measured number; measured number above the stated range.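

In this assay, the same replacement of hydrogen by chloro gave a 2.5-fold higher number from compound 3 to compound 4 (0.39 log units; beyond the scatter). The change therefore did not carry from one core to the other with the same direction or size, and a step read on one of these cores is a poor guide to the other: the same change on two cores in this assay, a 1.7-fold lower number (0.22 log units; within the scatter) from compound 1 to compound 2 and a 2.5-fold higher number (0.39 log units; beyond the scatter) from compound 3 to compound 4, 4.1-fold (0.62 log units) apart, beyond the scatter of two such steps. This rests on one pair per core and one position, and the step on the core of compound 1 is itself within the scatter, so the result shows that the two cores differ in their response to chloro, but it does not show why they differ or give a rule for other changes.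

The compounds shown leave open whether a different group on the same aromatic carbon, such as fluoro, methoxy or an amine, would also part ways between the two cores. They also leave open whether chloro at another carbon of that ring would show the same gap.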